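Extending the Amide Substituent of Compound 2

This account rests on a few compounds, and the source may have more. Where it says the series, first, only, none or still open, it means among the compounds named here.

Compound 1, `CN1C(=O)C(O)(Cc2nnn[nH]2)c2ccccc21`: 44800 nM in a functional assay on PC-3 cells (Homo sapiens) for antiproliferative activity, read by MTT assay, with a stated time of 48 h; a lower number here means a stronger inhibitor, a higher number a weaker inhibitor
Compound 2, `CN1C(=O)C(O)(Cc2nnn[nH]2)c2cc(F)ccc21`: 38200 nM in this assay

Among the measured compounds shown here, compound 2 and compound 1 cannot be told apart on these numbers: the only measured step, a 1.2-fold lower number from compound 1 to compound 2 (0.07 log units; within the scatter), lies within the scatter. Compound 3, `O=C1N(Cc2ccc(Br)cc2)c2ccc(F)cc2C1(O)Cc1nnn[nH]1`, differs from compound 2 by 4-bromophenyl in place of hydrogen on a saturated chain carbon bound to an amide-type nitrogen in a ring; read one bond further out, this is methyl to 4-bromobenzyl. For the measured compounds named here, no measured step concerns this part of the shared core; the fluoro step is the only one known and it bears on a different place. Going by the values given here, the expectation for compound 3 therefore rests on no direct precedent and must be held loosely. Compound 3 is tentatively expected to show a 2.5-fold lower number from compound 2 to compound 3 (0.41 log units; beyond the scatter) in this assay, with a wide range. The estimate for compound 3 in this assay is 15000 nM, between 2000 nM and 60000 nM.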

Compound 3, half-maximal inhibitory concentration: > 100000 nM
Compound 3 was reported as a limit; the forecaster's own chance of this, stated with the estimate: 10%; middle value at least 6.6-fold (0.82 log units) away from the limit.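

In this assay, compound 3 is reported only as a limit, > 100000 nM. The change from methyl to 4-bromobenzyl, the first change shown at this position of the shared core, gives an at least 2.6-fold higher number from compound 2 to compound 3 (0.41 log units; beyond the scatter). Unlike the fluoro change, which could not be told from the scatter, this change at the amide-type nitrogen moves the number clearly towards a weaker inhibitor, although its size is known only as a lower bound: the limit of > 100000 nM in this assay, at which 1 of the 3 values shown sits.

The compounds shown do not separate the contribution of the bromine from that of the phenyl ring, nor do they show how far compound 3 lies from compound 2. As far as these compounds go, how an unsubstituted benzyl group, or a short alkyl chain such as ethyl, on this nitrogen would read in this assay remains open.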